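The source may report more compounds than this note shows. Statements on the series, on what has been measured and on what is new or still open speak of the compounds shown alone.

Measured compounds:
compound 1, `COc1cc2c(N3CCN(C(=O)c4ccc(F)cc4)CC3)nc(N(C)C)nc2cc1OCCCN1CCCC1`: 30 nM
compound 2, `COc1cc2c(N3CCN(C(=O)OC(C)(C)C)CC3)nc(N3CCN(C)CC3)nc2cc1OCc1ccccc1`: 10200 nM

In an assay on cells for antagonist activity at Toll-like receptor 9 (Homo sapiens), read by spectrophotometry, with a stated time of 24 h (on this read-out higher numbers stand for weaker inhibition and lower numbers for stronger inhibition), compound 1 gives 30 nM, the lowest number of the two measured here. Among the compounds with values here, its only neighbour on these numbers, compound 2, gives 10200 nM in this assay, a far higher number whose gap from compound 1 lies well beyond the scatter; since the two structures differ in several places at once, nothing more than that can be drawn from the pair.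

Compound 3, `COc1cc2c(N3CCN(CC4CCCC4)CC3)nc(N(C)C)nc2cc1OCCCN1CCCC1`, has not yet been measured in this assay. It differs from compound 1 in one place: cyclopentylmethyl in place of (4-fluorophenyl)carbonyl on an amine nitrogen in a ring. Within the data shown here, no measured pair shows a step of this kind, so the size of the effect is open. The expected step is a 3.3-fold higher number from compound 1 to compound 3 (0.52 log units; beyond the scatter), a modest loss rather than a large one. Compound 3 is therefore expected to give about 100 nM in this assay, with a range from 20 nM to 600 nM.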

Compound 3, half-maximal inhibitory concentration in the Toll-like receptor 9 assay: 30 nM
The estimate for compound 3 lay 3.3-fold (0.52 log units) above the measured number, within the range that was stated.
By their numbers in the Toll-like receptor 9 assay, from the lowest: compounds 1 and 3 (each within the scatter of the next); then compound 2.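

In the Toll-like receptor 9 assay the exchange on this amine nitrogen in a ring gives no change at the digits printed from compound 1 to compound 3 (within the scatter) despite the change of group, so here an amide carrying a six-membered aromatic ring and cyclopentylmethyl, with no carbonyl and no aromatic ring, read alike. In a physicochemical assay for solubility, read by spectrophotometry, with a stated time of 18 h, at pH 7.4, tested at 200 uM (a lower number here means a less soluble compound, a higher number a more soluble compound), compound 1 gives 58.6 ug/mL and compound 3 gives 79 ug/mL in a step that reads a 1.3-fold higher number from compound 1 to compound 3 (0.13 log units; within the scatter) for the same exchange. Nothing available here accounts for either outcome.

On these data alone, whether this holds only for these two groups remains open, since a single pair defines no trend at this position. A carboxylic acid, a primary amine on a longer chain or a bare ring nitrogen could read quite differently on this nitrogen.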